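The source may hold more compounds than are shown below. What is called first, only, known or untested is meant among the compounds shown, and "the series" means these compounds.

Compound 1 `COc1cc(/C=C/C(=O)c2cc(-c3cc(OC)c(OC)c(OC)c3)n3nc(-c4ccccc4)cc3n2)cc(OC)c1OC` — 18400 nM
Compound 2 `COc1ccc(-c2cc(/C=C/C(=O)c3ccccc3)nc3cc(-c4ccccc4)nn23)cc1OC` — 11800 nM
Compound 3 `COc1ccc(/C=C/C(=O)c2cc(-c3cc(OC)c(OC)c(OC)c3)n3nc(-c4ccccc4)cc3n2)cc1OC` — 14200 nM

The three measured compounds were tested in a functional assay on MDA-MB-231 cells (Homo sapiens) for antiproliferative activity, read by MTT assay, with a stated time of 24 h; a lower number here means a stronger inhibitor, a higher number a weaker inhibitor. Compound 3 gives 14200 nM, which places it second highest of the three numbers; its nearest neighbour is compound 2, and the gaps to both compound 2 and compound 1 are within the usual scatter, so the three compounds cannot be separated from one another on these numbers.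

Compound 4 `COc1cc(-c2cc(C(=O)/C=C/c3ccc(Cl)cc3)nc3cc(-c4ccccc4)nn23)cc(OC)c1OC` is not yet measured. It differs from compound 3 in one place: 4-chlorophenyl in place of 3,4-dimethoxyphenyl on a double-bonded chain carbon bound to a double-bonded chain carbon.

Going by the values given here, the only measured step that changes a single group is a 1.3-fold lower number from compound 1 to compound 3 (0.11 log units; within the scatter), which removes one methoxy from the same aryl ring on the chain. Among the compounds with values here, it bears on the present change only loosely, since going from compound 3 to compound 4 removes both remaining methoxy groups and adds a chlorine, a change with no direct counterpart among the measured compounds. Within the data shown here, with the one available step within scatter and all three measured values close together, the expected step in this assay from compound 3 to compound 4 is a 1.2-fold lower number from compound 3 to compound 4 (0.07 log units; within the scatter), no clear direction beyond the scatter.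

Compound 4 is therefore estimated at 12000 nM, with a range from 4500 nM to 32000 nM.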

Compound 4, half-maximal inhibitory concentration: 21600 nM
The estimate for compound 4 lay 1.8-fold (0.26 log units) below the measured number; the range from low to high includes it.
By their numbers in this assay, from the lowest: compounds 2, 3, 1 and 4 (each within the scatter of the next).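

Going by these compounds alone, compound 4 is the first of compounds 1, 3 and 4 to carry a chlorine, and no methoxy group, on the ring at the end of the chain. Even so, in this assay replacing 3,4-dimethoxyphenyl with 4-chlorophenyl on a double-bonded chain carbon bound to a double-bonded chain carbon gives only a small step (a 1.5-fold higher number from compound 3 to compound 4 (0.18 log units; within the scatter)), and replacing 3,4,5-trimethoxyphenyl with the same group gives another (a 1.2-fold higher number from compound 1 to compound 4 (0.07 log units; within the scatter)), so across these compounds this position accepts rings with three, two or no methoxy groups without a change that can be told from the scatter. Nothing available here offers an explanation for this result.

The chlorine arrives in the same change that removes the methoxy groups, so the compounds shown cannot separate the contribution of each, and an unsubstituted phenyl at this position would be needed to do so. As far as these compounds go, it also remains open whether a different kind of group on this ring, such as an amine or a carboxylic acid, would shift the number beyond the scatter.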